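The compounds below may be only part of what the source reports. "The series", "measured", "known", "first", "only" and "open" are said of these compounds alone.

Measured in a functional assay on SK-OV-3 cells (Homo sapiens) for inhibition, read by CCK-8 assay, with a stated time of 70 h; a lower number here means a stronger inhibitor, a higher number a weaker inhibitor:

Compound 1 `O=[N+]([O-])c1cccc(COc2ccc(OCCOCCNC3CCCC3)cc2)c1` gives 15400 nM.
Compound 2 `c1ccc(COc2ccc(OCCOCCOC3CCCC3)cc2)cc1` shows only a limit of the assay, > 100000 nM.
Compound 3 `Nc1ccccc1COc1ccc(OCCOCCNC2CCCC2)cc1` gives 14000 nM.

Of the two numbers given, compound 3 has the lower one, but the gap between them is a 1.1-fold lower number from compound 1 to compound 3 (0.04 log units; within the scatter), within the scatter, so neither can be called the stronger inhibitor. Compound 4 `O=Cc1ccc(COc2ccc(OCCOCCNC3CCCC3)cc2)cc1` is the next compound; it differs from compound 3 in one place: 4-formylphenyl in place of 2-aminophenyl on a saturated chain carbon bound to an oxygen on an aromatic ring. Going by the values given here, the only measured step that bears on this, a 1.1-fold lower number from compound 1 to compound 3 (0.04 log units; within the scatter), swapped one aryl group for another at the same place and moved nothing beyond the scatter, so a similar swap here is expected to change little in this assay. Compound 4 is therefore estimated at 15000 nM, within 5000 nM to 50000 nM, an expected step of a 1.1-fold higher number from compound 3 to compound 4 (0.03 log units; within the scatter).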

Compound 4, half-maximal inhibitory concentration: 45000 nM
Estimate against measurement, compound 4: 3.0-fold (0.48 log units) below; low and high end bracket the measured number.
By their numbers in this assay, from the lowest: compounds 3 and 1 (each within the scatter of the next); then compound 4. At a limit, above all of these: compound 2.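

In this assay, the aryl group on this saturated chain carbon bound to an oxygen on an aromatic ring proves less free to change than the earlier swap suggested: 4-formylphenyl gives a 3.2-fold higher number from compound 3 to compound 4 (0.51 log units; beyond the scatter), and also a 2.9-fold higher number from compound 1 to compound 4 (0.47 log units; beyond the scatter). Both steps are modest but beyond the scatter, whereas 2-aminophenyl and 3-nitrophenyl could not be told apart. Nothing shown accounts for this weaker inhibition.

Going by these compounds, it remains open whether the formyl group or its ring position matters more. A 4-aminophenyl group would help separate the two.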